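Replacing a dichlorophenyl arm with a hydroxynaphthyl one

This account rests on a few compounds, and the source may have more. Where it says the series, first, only, none or still open, it means among the compounds named here.

Compound 2 `CN(C)CCn1cnnc1-c1cc(Oc2ccc(NC(=O)N/N=C/c3cccc(Cl)c3Cl)cc2F)ccn1` gives 13200 nM in a functional assay on U-87MG ATCC cells (Homo sapiens) for cytotoxicity, read by MTT assay, with a stated time of 72 h (on this read-out lower numbers stand for stronger inhibition and higher numbers for weaker inhibition), the highest of the two numbers measured, with compound 1 `CN(C)CCn1cnnc1-c1cc(Oc2ccc(NC(=O)N/N=C/c3ccccc3)cc2F)ccn1` giving 2250 nM. Among the measured compounds shown here, the step of a 5.9-fold higher number from compound 1 to compound 2 (0.77 log units; beyond the scatter) is the only measured change at this position and shows that adding two chlorine atoms to the phenyl raised the number. For the measured compounds named here, compound 3 `CN(C)CCn1cnnc1-c1cc(Oc2ccc(NC(=O)N/N=C/c3c(O)ccc4ccccc34)cc2F)ccn1` differs by 2-hydroxynaphthalen-1-yl in place of 2,3-dichlorophenyl on a carbon with a double bond to nitrogen, a change no measured step directly covers. Going by the values given here, with only one weak precedent, the number for compound 3 is estimated to sit between the two measured ones, at 6000 nM (range 1500 nM to 25000 nM), which would mean an expected step of a 2.2-fold lower number from compound 2 to compound 3 (0.34 log units; beyond the scatter).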

Compound 3, half-maximal inhibitory concentration: 620 nM
The estimate for compound 3 lay 9.7-fold (0.99 log units) above the measured number, outside the stated range (below it).
By their numbers in this assay, from the lowest: compound 3; then compound 1; then compound 2.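

Among the compounds shown here, until now, the only change at this position had raised the number, but the aryl group on this carbon with a double bond to nitrogen can also lower it. The 2-hydroxynaphthalen-1-yl group gives a 21-fold lower number from compound 2 to compound 3 (1.33 log units; beyond the scatter), and it also beats the plain phenyl, with a 3.6-fold lower number from compound 1 to compound 3 (0.56 log units; beyond the scatter). Nothing available explains this drop.

As far as these compounds go, the entering group brings a second ring and a hydroxyl together, so the contribution of each remains open. Plain naphthalen-1-yl and 2-hydroxyphenyl groups would separate the two.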